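Methyl to Ethyl on Two Amide Side Chains

A few compounds are considered here, and "the series" means these few. Any claim that something is new, unique, unknown or untested is made for them only; others in the source may bear on it.

Compound 1 `CNCC(=O)Nc1cc(OC)ccc1C(=O)c1ccc2c(c1)C=CC(C)(C)O2` and compound 2 `CCNCC(=O)Nc1cc(OC)ccc1C(=O)c1ccc2c(c1)C=CC(C)(C)O2` share one core; compound 3 `C=C(c1cc(OC)c(OC)c(OC)c1)c1ccc(OC)c(O)c1NC(=O)COC` and the unmeasured compound 4 `C=C(c1cc(OC)c(OC)c(OC)c1)c1ccc(OC)c(O)c1NC(=O)COCC` share another. The difference between the two cores is not broken down here. In a functional assay on A549 cells (Homo sapiens) for antiproliferative activity, read by MTT assay, with a stated time of 48 h (on this read-out higher numbers stand for weaker inhibition and lower numbers for stronger inhibition), compound 1 gives 800 nM, compound 2 gives 1300 nM and compound 3 gives 190 nM. The change from compound 1 to compound 2 is methyl in place of hydrogen on a saturated chain carbon bound to an amine nitrogen, and it made a 1.6-fold higher number from compound 1 to compound 2 (0.21 log units; within the scatter). The change from compound 3 to compound 4 is methyl in place of hydrogen on a saturated chain carbon bound to an oxygen on a saturated carbon, the same kind of change, though around its place the saturated chain carbon is bound to an oxygen on a saturated carbon rather than to an amine nitrogen. Resting on compound 1 and compound 2 with a 1.6-fold higher number from compound 1 to compound 2 (0.21 log units; within the scatter), the step for compound 4 is expected to be a 1.6-fold higher number from compound 3 to compound 4 (0.20 log units; within the scatter). Compound 4 is therefore estimated at 300 nM, between 150 nM and 600 nM.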

Compound 4, half-maximal inhibitory concentration: 880 nM
Compound 4: middle estimate off by 2.9-fold (0.47 log units), on the low side, outside the stated range (above it).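

Going from methoxy to ethoxy on the core of compound 3 gave a 4.6-fold higher number from compound 3 to compound 4 (0.67 log units; beyond the scatter) in this assay. Set beside the earlier step, the same change did not carry over at the same size: the same change on two cores in this assay, a 1.6-fold higher number (0.21 log units; within the scatter) from compound 1 to compound 2 and a 4.6-fold higher number (0.67 log units; beyond the scatter) from compound 3 to compound 4, 2.9-fold (0.45 log units) apart, beyond the scatter of two such steps. The step read on the core of compound 1 was therefore a poor guide to its size on the core of compound 3, but with one pair on each core this does not show whether the cores themselves or the amine nitrogen against the oxygen on a saturated carbon set the two steps apart.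

The compounds shown leave open how a longer chain, such as propoxy, would fare on the core of compound 3. They also leave open whether an amine in the side chain of that core would give a step like the one on the core of compound 1.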